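Ring-methyl removal in an aldosterone synthase inhibitor series

The compounds below may be only part of what the source reports. "The series", "measured", "known", "first", "only" and "open" are said of these compounds alone.

Measured compounds:
compound 1, `CC(=O)N[C@@H]1CCCc2c1cncc2N1CCc2cc(Cl)ccc2C1=O`, 54 nM
compound 2, `CC[C@@H]1c2cc(Cl)ccc2C(=O)N1c1cncc2c1CCC[C@H]2NC(C)=O`, 7 nM
compound 3, `CCC(=O)N[C@@H]1CCCc2c1cncc2N1CCc2cc(Cl)ccc2C1=O`, 119 nM

In an assay on cells for inhibition of cytochrome P450 11B2, mitochondrial (Homo sapiens), read by HTRF (a lower number here means a stronger inhibitor, a higher number a weaker inhibitor), compound 3 gives 119 nM and compound 1 gives 54 nM. The two differ only by hydrogen in place of methyl on a saturated chain carbon bound to a carbonyl carbon, and the step of a 2.2-fold lower number from compound 3 to compound 1 (0.34 log units; beyond the scatter) is modest but beyond the scatter. Compound 2 holds the lowest number of the three in this assay with 7 nM; the difference between its core and that of compound 3 is not broken down here, the two being built from the same atoms joined differently.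

Compound 4, `CC(=O)N[C@@H]1CCCc2c1cncc2N1C(=O)c2ccc(Cl)cc2[C@H]1C`, is not yet measured. It is reached from compound 2 by hydrogen in place of methyl on a saturated chain carbon bound to a saturated ring carbon. For the measured compounds named here, this is the same kind of change as the one from compound 3 to compound 1, but not the same: there the place was a saturated chain carbon bound to a carbonyl carbon, here it is a saturated chain carbon bound to a saturated ring carbon. Compound 1 carries hydrogen at the same ring carbon and acetyl on the amide, as compound 4 does, so compound 4 is expected to sit between compound 2 and compound 1 in this assay. The step of a 2.6-fold higher number from compound 2 to compound 4 (0.41 log units; beyond the scatter) is the expected change, a loss of potency because compound 1 shows 54 nM with the ring carbon bare. For compound 4 the expected value is 18 nM, with a likely range from 7 nM to 45 nM.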

Compound 4, half-maximal inhibitory concentration: 130 nM
Estimate against measurement, compound 4: 7.2-fold (0.86 log units) below, and the stated range ends below it.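

In this assay, cutting the ethyl group of compound 2 back to the methyl group of compound 4 is a large loss of potency (a 19-fold higher number from compound 2 to compound 4 (1.27 log units; beyond the scatter)). Hydrogen in place of methyl therefore does not carry a fixed effect from one core to another in this series, as the two steps run in opposite directions and differ by more than their scatter: the same change on two cores in this assay, a 2.2-fold lower number (0.34 log units; beyond the scatter) from compound 3 to compound 1 and a 19-fold higher number (1.27 log units; beyond the scatter) from compound 2 to compound 4, 41-fold (1.61 log units) apart, beyond the scatter of two such steps.
This does not show that the core alone sets the outcome, since the change sits on a saturated chain carbon bound to a carbonyl carbon in one pair and on a saturated chain carbon bound to a saturated ring carbon in the other, and each place is seen only once, on one core.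

The compounds shown leave open whether the same change at the same place gives matching steps on both cores, which a propanoyl amide on the core of compound 2 would test directly. Also open, on these data alone, is how the saturated ring carbon that carries ethyl in compound 2 responds to a longer chain such as propyl, to a cyclopropyl group, or to a hydroxymethyl group.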